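A Hydroxy Swap in a Level Series

The source may report more compounds than this note shows. Statements on the series, on what has been measured and on what is new or still open speak of the compounds shown alone.

Measured in a functional assay for inhibition, with Homo sapiens as the target; a lower number here means a stronger inhibitor, a higher number a weaker inhibitor:
- compound 1 `Cc1cc2c(cc1C(=O)N=C(N)N)S(=O)(=O)CC2(O)C(=O)c1ccccc1`: 157 nM
- compound 2 `Cc1cc2c(cc1C(=O)N=C(N)N)S(=O)(=O)CC2(C)O`: 115 nM
- compound 3 `Cc1cc2c(cc1C(=O)N=C(N)N)S(=O)(=O)CC2C`: 182 nM

Compound 3, at 182 nM, lies within the scatter of both other compounds, so these numbers do not separate the three. Compound 4 `Cc1cc2c(cc1C(=O)N=C(N)N)S(=O)(=O)CC2O` has hydroxy in place of methyl on a saturated ring carbon. Two measured steps at a saturated ring carbon bear on this change: a 1.4-fold lower number from compound 1 to compound 2 (0.14 log units; within the scatter) and a 1.6-fold higher number from compound 2 to compound 3 (0.20 log units; within the scatter). Both stay within the scatter, so no step beyond the scatter is expected in this assay. The expected change is a 1.2-fold lower number from compound 3 to compound 4 (0.08 log units; within the scatter). The estimated value for compound 4 is 150 nM, with an expected range of 70 nM to 320 nM.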

Compound 4, half-maximal inhibitory concentration: 1050 nM
Compound 4: middle estimate off by 7.0-fold (0.85 log units), on the low side; measured number above the stated range.
By their numbers in this assay, from the lowest: compounds 2, 1 and 3 (each within the scatter of the next); then compound 4.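

In this assay, among the compounds shown here, this saturated ring carbon is not indifferent to the group it carries: hydroxy in place of methyl gives the first step beyond the scatter (a 5.8-fold higher number from compound 3 to compound 4 (0.76 log units; beyond the scatter)). Compound 4 also stands apart from the two compounds that carry hydroxy plus a second group on that carbon, whether that group is methyl (a 9.1-fold higher number from compound 2 to compound 4 (0.96 log units; beyond the scatter)) or benzoyl (a 6.7-fold higher number from compound 1 to compound 4 (0.83 log units; beyond the scatter)). Hydroxy therefore does not go with the higher number in every compound, as compound 1 and compound 2 show.

Nothing here gives a reason for the higher number of compound 4. As far as these compounds go, whether an amine or a methoxy group on this carbon would behave like hydroxy or like methyl remains open.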